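A few compounds are considered here, and "the series" means these few. Any claim that something is new, unique, unknown or untested is made for them only; others in the source may bear on it.

Of the compounds shown here, three built on one shared core have been tested in a functional assay on HeLa cells (Homo sapiens) for cytotoxicity, read by MTT assay; a lower number here means a stronger inhibitor, a higher number a weaker inhibitor. Compound 1 `CC(C)=CC[C@@H](OC[C@H](C)O)C1=CC(=O)c2c(O)ccc(O)c2C1=O` gives 40300 nM, compound 2 `CCCC(O)CC(=O)O[C@H](CC=C(C)C)C1=CC(=O)c2c(O)ccc(O)c2C1=O` gives 59300 nM, and compound 3 `CC(C)=CC[C@@H](OC(=O)CC(C)(O)C(C)C)C1=CC(=O)c2c(O)ccc(O)c2C1=O` gives 27700 nM. For the measured compounds named here, compound 3 stands lowest of the three numbers, yet its distance from compound 1 is within the scatter, a 1.5-fold lower number from compound 1 to compound 3 (0.16 log units; within the scatter), and only the step of a 2.1-fold lower number from compound 2 to compound 3 (0.33 log units; beyond the scatter) is modest but real. The step of a 1.5-fold higher number from compound 1 to compound 2 (0.17 log units; within the scatter) also stayed within the scatter. Compound 4 `CC(=O)OC(C)CO[C@H](CC=C(C)C)C1=CC(=O)c2c(O)ccc(O)c2C1=O` differs from compound 3 in one place: 2-acetoxypropyl in place of (2-hydroxy-2,3-dimethylbutyl)carbonyl on an oxygen on a saturated carbon. Because the change from compound 1 to compound 3 gave only a 1.5-fold lower number from compound 1 to compound 3 (0.16 log units; within the scatter), the group at this oxygen appears to move the number little, so compound 4 is expected to land close to compound 3. The expected step is a 1.4-fold higher number from compound 3 to compound 4 (0.14 log units; within the scatter). The estimate for compound 4 is 38000 nM, ranging from 16000 nM to 90000 nM.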

Compound 4, half-maximal inhibitory concentration: 40100 nM
Compound 4: middle estimate off by 1.1-fold (0.02 log units), on the low side; measured number inside the range.
By their numbers in this assay, from the lowest: compounds 3, 4, 1 and 2 (each within the scatter of the next, the first and the last beyond it).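

In this assay, swapping the acyl groups on this oxygen for 2-acetoxypropyl stays within the scatter, both against compound 3 (a 1.4-fold higher number from compound 3 to compound 4 (0.16 log units; within the scatter)) and against compound 2 (a 1.5-fold lower number from compound 2 to compound 4 (0.17 log units; within the scatter)). Capping the hydroxyl of compound 1 as an acetate shows the same (a 1.0-fold lower number from compound 1 to compound 4 (0.00 log units; within the scatter)), so at this position a free hydroxyl on the chain is not required for the activity seen here. All four compounds therefore sit close together, with only compounds 2 and 3 printed as beyond the scatter of each other.

On these data alone, whether an amine or a carboxylic acid on this chain would shift the number stays open. No measurement at hand explains why these groups read so alike.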